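The source may report more compounds than this note shows. Statements on the series, on what has been measured and on what is new or still open speak of the compounds shown alone.

Measured compounds:
- compound 1, `CC(C)(C)OC(=O)N1C[C@H](O)C[C@H]1COCCCCCC/C=C/c1ccc(-c2ccccc2)cc1`, with 38500 nM in a functional assay on HeLa cells (Homo sapiens) for inhibition, with a stated time of 72 h; on this read-out higher numbers stand for weaker inhibition and lower numbers for stronger inhibition
- compound 2, `CC(C)(C)OC(=O)N1C[C@H](O)C[C@H]1COCCCCCCCCC/C=C/c1ccc(-c2ccccc2)cc1`, with 36500 nM in this assay
- compound 3, `CC(C)(C)OC(=O)N1C[C@H](O)C[C@H]1COCCCCCC/C=C/c1ccc(Oc2ccccc2)cc1`, with 41000 nM in this assay

All three measured compounds share the same protected ring bearing a hydroxyl group, linked through an ether to a long chain that ends in a double bond attached to an aromatic ring. Compound 1 and compound 3 differ in one place only: phenoxy in place of phenyl on an aromatic carbon. The step that this change made is a 1.1-fold higher number from compound 1 to compound 3 (0.03 log units; within the scatter), so on this read-out the two compounds cannot be told apart. Compound 2 carries the same end group as compound 1 but differs from it in the core, and the difference between the two cores is not broken down here; what the numbers show is that compound 1 and compound 2 lie within the scatter of each other.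

Compound 4, `CC(C)(C)OC(=O)N1C[C@H](O)C[C@H]1COCCCCCCCCC/C=C/c1ccc(Oc2ccccc2)cc1`, has not yet been measured. It differs from compound 2 by phenoxy in place of phenyl on an aromatic carbon, which is the same change that turns compound 1 into compound 3, made at the same kind of place. Because the earlier step was a 1.1-fold higher number from compound 1 to compound 3 (0.03 log units; within the scatter), the step from compound 2 to compound 4 is expected to be of the same small size, a 1.1-fold higher number from compound 2 to compound 4 (0.04 log units; within the scatter). Compound 4 is therefore estimated at 40000 nM, with a likely range from 20000 nM to 80000 nM.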

Compound 4, half-maximal inhibitory concentration: 45900 nM
Estimate against measurement, compound 4: 1.1-fold (0.06 log units) below; the measured number falls inside the stated range.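

In this assay, putting phenoxy in place of phenyl on the core of compound 2 gives a 1.3-fold higher number from compound 2 to compound 4 (0.10 log units; within the scatter), so on this read-out the two compounds cannot be told apart. Set beside the earlier step, the change looks the same on both cores, and nothing here separates the two results: the same change on two cores in this assay, a 1.1-fold higher number (0.03 log units; within the scatter) from compound 1 to compound 3 and a 1.3-fold higher number (0.10 log units; within the scatter) from compound 2 to compound 4, 1.2-fold (0.07 log units) apart, within the scatter of two such steps. This shows that the swap can be carried between these two cores without a readable shift in the number, but only in the sense that it has no measurable effect on either; it does not show that a change with a real effect would carry over in the same way, and two cores say nothing about any others in the series.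

The compounds shown leave open whether any change at the far end of the chain can move the number beyond the scatter, for instance an amine or a carboxylic acid in place of the terminal phenyl ring. For the compounds shown here, they also leave open whether a longer chain than the one in compound 2, or a free ring amine in place of the protected one, would do so.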